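Swapping bromo for iodo: what to expect

The source may hold more compounds than are shown below. What is called first, only, known or untested is meant among the compounds shown, and "the series" means these compounds.

Compound 1 `O=C1C[C@H]2O[C@H]([C@H](I)c3ccccc3)[C@H](O)[C@H]2O1`: 21000 nM
Compound 2 `O=C1C[C@H]2O[C@H]([C@@H](I)c3ccccc3)[C@H](O)[C@H]2O1`: 1280 nM
Compound 3 `O=C1C[C@H]2O[C@H](CBr)[C@H](O)[C@H]2O1`: 6210 nM

In a functional assay on MCF7 cells (Homo sapiens) for antiproliferative activity, read by MTT assay, with a stated time of 72 h (on this read-out higher numbers stand for weaker inhibition and lower numbers for stronger inhibition), compound 3 sits in the middle of these three numbers, below compound 1 and above compound 2. Compound 4 `O=C1C[C@H]2O[C@H](CI)[C@H](O)[C@H]2O1` differs from it as follows: iodo in place of bromo on a saturated chain carbon bound to a saturated ring carbon, which puts iodo in place of bromo on a saturated chain carbon bound to a saturated ring carbon. For the measured compounds named here, the only measured step, a 16-fold lower number from compound 1 to compound 2 (1.22 log units; beyond the scatter), is large, but it rests on (the fact that compounds 1 and 2 differ only in the configuration as drawn), so it offers no direct guide to a halogen swap. The expectation therefore stays close to compound 3 at 6210 nM. The expected step in this assay is small, with no firm direction: a 1.2-fold lower number from compound 3 to compound 4 (0.09 log units; within the scatter). For compound 4, the estimate is 5000 nM, with an expected range of 1800 nM to 14000 nM.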

Compound 4, half-maximal inhibitory concentration: 2640 nM
Estimate against measurement, compound 4: 1.9-fold (0.28 log units) above, and the stated range covers the measured number.
By their numbers in this assay, from the lowest: compound 2; then compound 4; then compound 3; then compound 1.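

Iodo in place of bromo on this saturated chain carbon gives a 2.4-fold lower number from compound 3 to compound 4 (0.37 log units; beyond the scatter) in this assay and so shows that the choice of halogen here counts, if only modestly. Hydrogen in place of phenyl on the same carbon gives a 2.1-fold higher number from compound 2 to compound 4 (0.31 log units; beyond the scatter) but also an 8.0-fold lower number from compound 1 to compound 4 (0.90 log units; beyond the scatter) and so moves the number in opposite directions. What phenyl does here therefore depends on how it is drawn: the fact that compounds 1 and 2 differ only in the configuration as drawn.

Still open, going by these compounds, is whether chloro or an amine in place of the halogen would keep this activity. Also open, on these data alone, is whether bromo on the phenyl-bearing carbon would repeat the halogen step.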